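The source may report more compounds than this note shows. Statements on the series, on what has been measured and on what is new or still open speak of the compounds shown alone.

Measured compounds:
Compound 1, `O=C(NCCNS(=O)(=O)c1ccc(-c2ccccc2Oc2ccc([N+](=O)[O-])c([N+](=O)[O-])c2)s1)Nc1ccc(Cl)cc1`: in a functional assay on HL-60 cells (Homo sapiens) for inhibition, read by CCK-8 assay, with a stated time of 48 h (on this read-out lower numbers stand for stronger inhibition and higher numbers for weaker inhibition), compound 1 gives 8100 nM.
Compound 2, `Cc1cc(C)cc(NC(=O)NCCNS(=O)(=O)c2ccc(-c3ccccc3Oc3ccc([N+](=O)[O-])c([N+](=O)[O-])c3)s2)c1`: in this assay compound 2 gives 9100 nM.
Compound 3, `COc1ccc(NC(=O)NCCNS(=O)(=O)c2ccc(-c3ccccc3Oc3ccc([N+](=O)[O-])c([N+](=O)[O-])c3)s2)cc1`: in this assay compound 3 gives 5400 nM.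

Compound 3 holds the lowest of the three numbers, but its distance to compound 1 and its distance to compound 2 both lie within the scatter, so the three values cannot be put in order. The three compounds share one core and differ only in the group on an amide-type nitrogen.

Compound 4, `O=C(NCCNS(=O)(=O)c1ccc(-c2ccccc2Oc2ccc([N+](=O)[O-])c([N+](=O)[O-])c2)s1)Nc1ccc([N+](=O)[O-])cc1`, has not been measured. Relative to compound 3 the change is nitro in place of methoxy on an aromatic carbon.

All measured steps exchange the substituent on that same ring: a 1.5-fold lower number from compound 1 to compound 3 (0.18 log units; within the scatter), a 1.7-fold lower number from compound 2 to compound 3 (0.23 log units; within the scatter) and a 1.1-fold higher number from compound 1 to compound 2 (0.05 log units; within the scatter). Each stayed within the scatter. Chloro, methoxy and dimethyl substitution thus left the read-out unchanged; nitro has not been tried, and nothing here points to a direction. For compound 4 the expected step is a 1.3-fold higher number from compound 3 to compound 4 (0.11 log units; within the scatter) in this assay, that is, no movement beyond the scatter. Compound 4 is estimated at 7000 nM, within 3000 nM to 16000 nM.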

Compound 4, half-maximal inhibitory concentration: 340 nM
For compound 4 the middle estimate is 21-fold (1.31 log units) above the measured one, outside the stated range (below it).
By their numbers in this assay, from the lowest: compound 4; then compounds 3, 1 and 2 (each within the scatter of the next).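

In this assay the group at this place on the ring is not indifferent: the series shows a 16-fold lower number from compound 3 to compound 4 (1.20 log units; beyond the scatter) with nitro in place of methoxy, a 24-fold lower number from compound 1 to compound 4 (1.38 log units; beyond the scatter) with nitro in place of chloro and a 27-fold lower number from compound 2 to compound 4 (1.43 log units; beyond the scatter) with 4-nitrophenyl in place of 3,5-dimethylphenyl. All three steps lie beyond the scatter while the steps among compounds 1, 2 and 3 stay within it, so among these four compounds nitro alone sets a compound apart, and compound 4 is the most potent of them. Going by these compounds alone, no measurement at hand accounts for this one exchange moving the number so far.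

On these data alone, whether the low number belongs to nitro alone or also appears with a nitrile, a trifluoromethyl or an amine at this place remains open. Also open, as far as these compounds go, is whether the same exchange keeps a step of this size with a longer chain in the shared core.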